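The compounds below may be only part of what the source reports. "The series", "measured", "known", "first", "only" and "open" are said of these compounds alone.

Measured in an assay for inhibition of Indoleamine 2,3-dioxygenase 1 (Homo sapiens), with stated times of 10 min and 60 min, tested at 10 uM; a higher number here means a stronger effect of the compound at the concentration tested, a lower number a weaker effect:
Compound 1 `FC(F)(F)c1cc(NC[C@H]2CCCN2)c2cn[nH]c2c1` gives 34%.
Compound 2 `FC(F)(F)c1cccc(CNc2cc(C(F)(F)F)cc3[nH]ncc23)c1` gives 25%.
Compound 3 `FC(F)(F)c1cc(NCC2CNC2)c2cn[nH]c2c1` gives 10%.

Within the data shown here, compound 3 stands lowest of the three: compound 2 sits beyond the scatter above it, and compound 1 is further still, the one measured step being a number 24 percentage points lower from compound 1 to compound 3 (beyond the scatter). Compound 4 `FC(F)(F)c1cc(NCc2cccc(Br)c2)c2cn[nH]c2c1` differs from compound 3 by 3-bromophenyl in place of azetidin-3-yl on a saturated chain carbon bound to a nitrogen on an aromatic ring. Among the measured compounds shown here, no measured step matches this change directly. The nearest guide is compound 2, which carries an aromatic ring at the same place and gives 25%; set against compound 3 this suggests a rise. For compound 4 in this assay the expected step is therefore a number 15 percentage points higher from compound 3 to compound 4 (beyond the scatter), upward but modest. Compound 4 is estimated at 25%, within 8% to 42%.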

Compound 4, a percentage reported as inhibition, at one concentration (the size of the read-out at that concentration, not a potency): 23%
Beside the measured number, compound 4's estimate is 2 percentage points above it, within the range that was stated.
By their numbers in this assay, from the lowest: compound 3; then compounds 4, 2 and 1 (each within the scatter of the next, the first and the last beyond it).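

In this assay the 3-bromophenyl group at this place scores above azetidin-3-yl, with a number 13 percentage points higher from compound 3 to compound 4 (beyond the scatter) on the same core, but under pyrrolidin-2-yl, with a number 11 percentage points lower from compound 1 to compound 4 (beyond the scatter) on that core. With a number 2 percentage points lower from compound 2 to compound 4 (within the scatter) for bromo in place of trifluoromethyl on an aromatic carbon, the two compounds stand level, so this swap on the aromatic ring shows no measurable difference. Still open, from the compounds shown here alone, is what this assay would show for a carboxylic acid or a longer chain at this place. Nothing measured here explains these steps.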